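The compounds below may be only part of what the source reports. "The series", "measured", "known", "first", "only" and "open" are said of these compounds alone.

Series notes, cytotoxicity. Compound 1 `Cc1ccc(-c2cn(/N=C/c3cc4ccccc4nc3Cl)c(N)n2)cc1` in an ADME assay on HUVEC cells (Homo sapiens) for cytotoxicity, read by MTT assay, with a stated time of 48 h (on this read-out lower numbers stand for stronger inhibition and higher numbers for weaker inhibition), gives only a limit, > 50000 nM. Compound 2 `Nc1nc(-c2ccc(Cl)cc2)cn1/N=C/c1cc2ccccc2nc1Cl` in this assay gives 28000 nM, and compound 3 `Cc1ccc(-c2cn(/N=C/c3cc4cc(C)ccc4nc3Cl)c(N)n2)cc1` gives 18000 nM. Among the two numbers shown, compound 3 has the lowest, with compound 2 nearest and within the scatter of it; compound 1 contributes only its limit (the limit of > 50000 nM in this assay, at which 1 of the 3 values shown sits).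

Compound 4 `Cc1ccc2nc(Cl)c(/C=N/n3cc(-c4ccc(Br)cc4)nc3N)cc2c1` is compound 3 with bromo in place of methyl on an aromatic carbon, that is, 4-methylphenyl to 4-bromophenyl. The closest measured step is an at least 1.7-fold lower number from compound 1 to compound 2 (0.25 log units; that floor lies within the scatter), a halogen in place of methyl at the same position, read against a limit so that its floor is within the scatter. The other step, an at least 2.7-fold lower number from compound 1 to compound 3 (0.44 log units; beyond the scatter), concerns methyl in place of hydrogen elsewhere and bears only loosely here. On that basis a small step toward a lower number, if any beyond the scatter, is expected for this assay, a 1.4-fold lower number from compound 3 to compound 4 (0.14 log units; within the scatter). Compound 4 is therefore estimated at 13000 nM, with a range from 5000 nM to 35000 nM.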

Compound 4, half-maximal inhibitory concentration: 13400 nM
Compound 4: middle estimate off by 1.0-fold (0.01 log units), on the low side; the measured number falls inside the stated range.
By their numbers in this assay, from the lowest: compounds 4, 3 and 2 (each within the scatter of the next, the first and the last beyond it). At a limit, above all of these: compound 1.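

In this assay, the change from 4-methylphenyl to 4-bromophenyl can be read between two actual numbers, unlike the earlier halogen-for-methyl step: a 1.3-fold lower number from compound 3 to compound 4 (0.13 log units; within the scatter). Compound 3 and compound 4 are therefore not separated, so on the core of compound 3, bromo and methyl at this position cannot be told apart in this read-out. The earlier step gave only a floor, as its starting point, compound 1, stands at a limit: the limit of > 50000 nM in this assay, at which 1 of the 4 values shown sits.

The compounds shown leave open whether an amine or a carboxylic acid at this position would move the number in this assay beyond the scatter. They also leave open whether bromo would read the same on the core of compound 1.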